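The compounds below may be only part of what the source reports. "The series", "measured", "known", "first", "only" and "open" are said of these compounds alone.

Compound 1 `O=C(Nc1ccc(-n2ncc3c(Cl)cccc32)cc1)Nc1ccc(Cl)c(C(F)(F)F)c1` gives 4600 nM; compound 2 `O=C(Nc1ccc(-n2ncc3c(F)cccc32)cc1)Nc1ccc(Cl)c(C(F)(F)F)c1` gives 8200 nM; compound 3 `Cc1cccc2c1cnn2-c1ccc(NC(=O)Nc2ccc(Cl)c(C(F)(F)F)c2)cc1` gives 32000 nM.

In a functional assay on HT-29 cells (Homo sapiens) for cytotoxicity, read by MTT assay, with a stated time of 72 h (on this read-out lower numbers stand for stronger inhibition and higher numbers for weaker inhibition), compound 3 stands highest of the three, beyond the scatter from both others. Compound 4 `O=C(Nc1ccc(-n2ncc3ccncc32)cc1)Nc1ccc(Cl)c(C(F)(F)F)c1` differs from compound 3 in that (a group of 9 heavy atoms (6 carbon, 3 nitrogen; one five-membered aromatic ring with 2 hetero atoms, one six-membered aromatic ring with 1 hetero atom) in place of a group of 10 heavy atoms (8 carbon, 2 nitrogen; one five-membered aromatic ring with 2 hetero atoms, one six-membered aromatic ring of carbon only), on an aromatic carbon). For the measured compounds named here, no measured step bears directly on this change: the known steps, a 1.8-fold higher number from compound 1 to compound 2 (0.25 log units; within the scatter), a 7.0-fold higher number from compound 1 to compound 3 (0.84 log units; beyond the scatter) and a 3.9-fold higher number from compound 2 to compound 3 (0.59 log units; beyond the scatter), each swap one small substituent on the same ring, and none removes it or alters the ring itself. Because compound 3 stands at 32000 nM while its halogen analogues lie lower, the expected step is a 2.1-fold lower number from compound 3 to compound 4 (0.33 log units; beyond the scatter), a modest fall in the number with wide uncertainty. Compound 4 is therefore estimated at 15000 nM, ranging from 4000 nM to 60000 nM.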

Compound 4, half-maximal inhibitory concentration: 29500 nM
Compound 4: the middle estimate sits 2.0-fold (0.29 log units) below what was measured; low and high end bracket the measured number.
By their numbers in this assay, from the lowest: compounds 1 and 2 (each within the scatter of the next); then compounds 4 and 3 (each within the scatter of the next).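

In this assay, replacing the 4-methyl-1H-indazol-1-yl group with the group of compound 4, whose six-membered ring holds a hetero atom, makes no difference beyond the scatter (a 1.1-fold lower number from compound 3 to compound 4 (0.04 log units; within the scatter)). Compound 4 instead stands apart from both halogen compounds (a 3.6-fold higher number from compound 2 to compound 4 (0.56 log units; beyond the scatter); a 6.4-fold higher number from compound 1 to compound 4 (0.81 log units; beyond the scatter)), so the two halogen compounds alone keep numbers beyond the scatter from it. No evidence is available to explain this result.

As far as these compounds go, compound 4 changes the ring atom and removes the substituent together, so the contribution of each remains open. An amine or a methoxy group at this position also remains untested in the compounds shown here.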